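A few compounds are considered here, and "the series" means these few. Any claim that something is new, unique, unknown or untested is made for them only; others in the source may bear on it.

Compound 3, with the structure `CCCNCC(=O)N1N=C(c2cc3ccccc3oc2=O)CC1c1ccccc1`, is measured in a functional assay on PC-3 cells (Homo sapiens) for cytotoxicity, read by MTT assay, with a stated time of 48 h (a lower number here means a stronger inhibitor, a higher number a weaker inhibitor), at 7270 nM. Compound 1, `CCC(=O)N1N=C(c2cc3ccccc3oc2=O)CC1c1ccccc1`, gives in this assay 4370 nM, and compound 2, `O=C(c1ccccc1Cl)N1N=C(c2cc3ccccc3oc2=O)CC1c1ccccc1`, gives 6370 nM. The differences among the three are all within the usual scatter: a 1.7-fold higher number from compound 1 to compound 3 (0.22 log units; within the scatter), a 1.1-fold higher number from compound 2 to compound 3 (0.06 log units; within the scatter) and a 1.5-fold higher number from compound 1 to compound 2 (0.16 log units; within the scatter), so compound 3 is not set apart from either neighbour. Compound 4, `O=C(CN1CCCC1)N1N=C(c2cc3ccccc3oc2=O)CC1c1ccccc1`, differs from compound 3 by one change: pyrrolidin-1-yl in place of propylamino on a saturated chain carbon bound to a carbonyl carbon. Among the measured compounds shown here, the steps that bear on this place are those that alter the group on the saturated chain carbon bound to the carbonyl carbon or the carbonyl substituent as a whole, namely a 1.7-fold higher number from compound 1 to compound 3 (0.22 log units; within the scatter) and a 1.1-fold higher number from compound 2 to compound 3 (0.06 log units; within the scatter), both within the scatter. On that basis no step beyond the scatter is expected for a 1.0-fold lower number from compound 3 to compound 4 (0.02 log units; within the scatter). Compound 4 is therefore estimated in this assay at 7000 nM, with a range from 3000 nM to 16000 nM.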

Compound 4, half-maximal inhibitory concentration: 50200 nM
Compound 4: the middle estimate sits 7.2-fold (0.86 log units) below what was measured; the measured number lies above the stated range.
By their numbers in this assay, from the lowest: compounds 1, 2 and 3 (each within the scatter of the next); then compound 4.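

In this assay, among the compounds shown here, the saturated chain carbon bound to a carbonyl carbon now proves sensitive to its substituent, which the earlier compounds did not show: pyrrolidin-1-yl in place of propylamino gives a 6.9-fold higher number from compound 3 to compound 4 (0.84 log units; beyond the scatter). The other new steps, a 7.9-fold higher number from compound 2 to compound 4 (0.90 log units; beyond the scatter) and an 11-fold higher number from compound 1 to compound 4 (1.06 log units; beyond the scatter), set compound 4 apart from all three earlier compounds, and since compound 3 also carries a nitrogen on this carbon yet stays within the scatter of compound 1, the nitrogen alone does not account for the difference. No measurement shown here explains this step.

The change adds a ring and removes the hydrogen-bond donor together, so the compounds shown cannot separate the two. A diethylamino group would have no donor and no ring, while a piperidin-1-yl or morpholin-4-yl group would test whether the result extends to other rings.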